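This account rests on a few compounds, and the source may have more. Where it says the series, first, only, none or still open, it means among the compounds named here.

Compounds measured so far:

Compound 1, `Cc1cc(-c2ccccc2)n(/C(N)=N/S(=O)(=O)c2cc(C)c(Cl)cc2SCc2cccc3ccccc23)n1`: 7000 nM
Compound 2, `Cc1cc(-c2ccccc2)n(/C(N)=N/S(=O)(=O)c2cc(C)c(Cl)cc2SCc2ccc(C(F)(F)F)cc2)n1`: 7000 nM

Both were tested in a functional assay on HCT-116 cells (Homo sapiens) for cytotoxicity, read by MTT assay, with a stated time of 72 h; on this read-out higher numbers stand for weaker inhibition and lower numbers for stronger inhibition. Compound 2 stands level with compound 1 at the digits shown, since the one measured step, no change at the digits printed from compound 1 to compound 2 (within the scatter), swapped one aromatic group for another on the saturated chain carbon bound to a sulfur without moving the read-out beyond the scatter.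

Compound 3, `Cc1cccc(CSc2cc(Cl)c(C)cc2S(=O)(=O)/N=C(\N)n2nc(C)cc2-c2ccccc2)c1`, has not yet been measured. It arises from compound 2 by the change (3-methylphenyl in place of 4-(trifluoromethyl)phenyl on a saturated chain carbon bound to a sulfur), that is, at the same place that was altered between compound 1 and compound 2. Going by the values given here, the one step that bears on this change is no change at the digits printed from compound 1 to compound 2 (within the scatter); it exchanged a larger aromatic group for a smaller one at this position and left the value unchanged within the scatter. On that basis no step beyond the scatter is expected here either: the expected step is no change at the digits printed from compound 2 to compound 3 (within the scatter), lying within the usual scatter. Compound 3 is therefore estimated to give 7000 nM, with a range from 3000 nM to 16000 nM.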

Compound 3, half-maximal inhibitory concentration: 34000 nM
Compound 3: middle estimate off by 4.9-fold (0.69 log units), on the low side; measured number outside the range, above it.
By their numbers in this assay, from the lowest: compounds 1 and 2 (each within the scatter of the next); then compound 3.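

In this assay, the aromatic group on the saturated chain carbon bound to a sulfur does matter: 3-methylphenyl in place of 4-(trifluoromethyl)phenyl gives a 4.9-fold higher number from compound 2 to compound 3 (0.69 log units; beyond the scatter) and 3-methylphenyl in place of naphthalen-1-yl gives a 4.9-fold higher number from compound 1 to compound 3 (0.69 log units; beyond the scatter) on the same read-out, both beyond the scatter and both towards weaker inhibition. The level result for compound 1 and compound 2 therefore does not hold for every aromatic group at this position, and compound 3 stands apart from both as the weakest of the three. Nothing measured here explains why this group behaves differently from the other two.

The swap from 4-(trifluoromethyl)phenyl to 3-methylphenyl alters both the group on the ring and the number of its ring position in a single change, and the compounds shown do not separate these two differences. From the compounds shown here alone, it also remains open whether an unsubstituted phenyl, a chlorophenyl or a longer chain between the sulfur and the ring would read like compound 1 and compound 2 or like compound 3.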